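The source may hold more compounds than are shown below. What is called first, only, known or untested is meant among the compounds shown, and "the series" means these compounds.

For the measured compounds named here, in a functional assay on MOLT-4 cells (Homo sapiens) for inhibition, read by MTT assay, with a stated time of 48 h (a lower number here means a stronger inhibitor, a higher number a weaker inhibitor), three compounds have numbers so far. Compound 1 (`CC(C)CCn1cc(/C=C/C(=O)CC(=O)C(=O)O)c2ccccc21`) gives 20000 nM, compound 2 (`O=C(/C=C/c1cn(Cc2ccccc2)c2ccccc12)CC(=O)C(=O)O`) gives 15000 nM, and compound 3 (`CCOC(=O)C(=O)CC(=O)/C=C/c1cc(C(=O)c2ccccc2F)c[nH]1`) gives 15000 nM. Compound 3 thus stands level with compound 2, and all three lie within the scatter of one another.

Compound 4 (`O=C(/C=C/c1cc(C(=O)c2ccccc2F)c[nH]1)CC(=O)C(=O)O`) is compound 3 with hydrogen in place of ethyl on an oxygen next to a carbonyl group. In other words, (ethoxycarbonyl)carbonyl becomes carboxycarbonyl, the end group that compound 1 and compound 2 already carry, though on a different core.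

Going by the values given here, no measured step covers this change directly. The only one available, a 1.3-fold lower number from compound 1 to compound 2 (0.12 log units; within the scatter), is phenyl in place of isobutyl on a saturated chain carbon bound to an aromatic nitrogen, a change elsewhere in the structure, so it bears on the question only weakly. The better guide is that compound 1 at 20000 nM and compound 2 at 15000 nM sit with compound 3 despite their carboxycarbonyl group. On that basis, no step beyond the scatter is expected in this assay.

The expected outcome is a 1.3-fold higher number from compound 3 to compound 4 (0.12 log units; within the scatter). For compound 4 the estimated value is 20000 nM, with an expected range from 8000 nM to 70000 nM.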

Compound 4, half-maximal inhibitory concentration: 20000 nM
Compound 4: the middle estimate sits on the measured number at the digits printed; the range from low to high includes it.
By their numbers in this assay, from the lowest: compounds 2, 3, 1 and 4 (each within the scatter of the next).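

In this assay, for the compounds shown here, the step of a 1.3-fold higher number from compound 3 to compound 4 (0.12 log units; within the scatter) gives the first direct comparison of (ethoxycarbonyl)carbonyl and carboxycarbonyl on a single core, and the two groups cannot be told apart there. Compound 1 and compound 2 carry carboxycarbonyl on a different core, so they could suggest this result only indirectly, whereas this pair differs in one place alone: hydrogen in place of ethyl on an oxygen next to a carbonyl group. No available measurement bears on why the two compounds read alike.

The compounds shown leave open whether a longer chain such as butyl on this oxygen, or an amine in place of the ethoxy, would also stay within the scatter of compound 3. They also leave open whether ethoxycarbonyl in place of carboxy would read the same on the core of compound 1 or compound 2, and so whether the result for this pair extends beyond the core of compound 3.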